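The source may report more compounds than this note shows. Statements on the series, on what has been measured and on what is new or still open speak of the compounds shown alone.

Measured in a functional assay on the whole organism with Mus musculus as the target; on this read-out lower numbers stand for an effect already at smaller amounts and higher numbers for an effect only at larger amounts of compound:
- Compound 1 `CC(C)NC(=O)/C=C1\CCc2ccc(F)cc21`: 96 mg/kg
- Compound 2 `O=C(/C=C1\CCc2ccc(F)cc21)NC1CCC1`: > 100 mg/kg, a limit and not a number
- Compound 3 `NC(=O)/C=C1\CCc2cc(F)ccc21`: 56 mg/kg

Compound 2 has no number in this assay and stands at the limit of > 100 mg/kg in this assay, at which 1 of the 3 values shown sits. The next compound to consider is compound 4 `CCCNC(=O)/C=C1\CCc2ccc(F)cc21`, reached through the change (propyl in place of cyclobutyl on an amide-type nitrogen), in words propyl in place of cyclobutyl on an amide-type nitrogen. Going by the values given here, one measured step bears on this change: an at least 1.0-fold higher number from compound 1 to compound 2 (0.01 log units; that floor lies within the scatter), for cyclobutyl in place of isopropyl at the same place. That step is known only as a floor, so it gives no true size. Compound 3 differs from compound 2 in more than one place and does not bear on the change. With compound 1 at 96 mg/kg as the nearest measured neighbour, no step beyond the scatter is expected in this assay, in either direction. The expected step is an at least 1.1-fold lower number from compound 2 to compound 4 (0.07 log units; that floor lies within the scatter). For compound 4 the estimate is 85 mg/kg, with an expected range of 40 mg/kg to 170 mg/kg.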

Compound 4, dose for half-maximal effect: > 100 mg/kg
Compound 4: a limit, no number; the forecaster's own chance of this, stated with the estimate: 35%; middle value at least 1.1-fold (0.07 log units) from the limit.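

In this assay compound 4 gives > 100 mg/kg, a limit and not a number, so removing the four-membered ring while keeping an alkyl chain on the amide-type nitrogen does not bring a number back on this read-out. Propyl in place of isopropyl gives an at least 1.0-fold higher number from compound 1 to compound 4 (0.01 log units; that floor lies within the scatter), a floor and not a true size, and the step between the two limits cannot be read. The limit is now reached with both a ring and an open chain at this position: the limit of > 100 mg/kg in this assay, at which 2 of the 4 values shown sit.

From the compounds shown here alone, whether a methyl group, a 2-hydroxyethyl chain or a 2-aminoethyl chain on the amide-type nitrogen gives a number in this assay stays open. Compound 3 gives 56 mg/kg but differs from compound 4 in more than one place, so it does not settle that question.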